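Notes on a methyl step from compound 2

The source may hold more compounds than are shown below. What is called first, only, known or untested is meant among the compounds shown, and "the series" means these compounds.

- compound 1 `Clc1ccc(-c2cc(-c3ccsc3)nc(-c3cccs3)c2)o1`: > 100000 nM
- compound 2 `Cc1ccsc1-c1cc(-c2ccco2)cc(-c2cccs2)n1`: 56400 nM

Among the measured compounds shown here, both compounds have been tested in a functional assay on HCT-116 cells (Homo sapiens) for cytotoxicity, with a stated time of 3 days; a lower number here means a stronger inhibitor, a higher number a weaker inhibitor. Compound 1 gives > 100000 nM, which is a limit of the assay and not a number. For the measured compounds named here, compound 2 gives 56400 nM, the only true number available so far, so it has no other number to be compared with.

The next compound to be tested is compound 3 `Cc1ccsc1-c1cc(-c2ccco2)cc(-c2sccc2C)n1`. It differs from compound 2 in one place, where thiophen-2-yl becomes 3-methylthiophen-2-yl (methyl in place of hydrogen on an aromatic carbon). This puts methyl in place of hydrogen on an aromatic carbon, next to the ring atom that bears a large group.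

Going by the values given here, no measured pair differs in one place only, so the size of this step has no direct precedent. The working expectation is therefore no change beyond the usual scatter, with no firm direction. The expected step is a 1.1-fold lower number from compound 2 to compound 3 (0.05 log units; within the scatter). For compound 3 the estimated value is 50000 nM, with an expected range from 20000 nM to 100000 nM.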

Compound 3, half-maximal inhibitory concentration: > 100000 nM
Compound 3: only a limit was reported; the forecaster's own chance of this, stated with the estimate: 25%; middle value at least 2.0-fold (0.30 log units) away from the limit.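

Among the compounds shown here, the methyl step gives the first pair that differs in one place, and in this assay it reads as an at least 1.7-fold higher number from compound 2 to compound 3 (0.24 log units; that floor lies within the scatter). Going by these compounds, for compound 3, > 100000 nM is a limit of the assay and not a number, so this 3-methylthiophen-2-yl change shows no gain over thiophen-2-yl at this position, though its true size remains unknown. The step can be read only as a floor: the limit of > 100000 nM in this assay, at which 2 of the 3 values shown sit.

On these data alone, whether an amine or a carboxylic acid in place of this methyl would give a lower number than compound 2 stays open. With compound 2 still the only compound carrying a true number, the compounds shown define no trend at this position.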